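The compounds below may be only part of what the source reports. "The series", "measured", "known", "first", "only" and "open" are said of these compounds alone.

Values in an ADME assay on THP-1 cells (Homo sapiens) for cytotoxicity; a higher number here means that more compound is tolerated, a lower number that less compound is tolerated:
- compound 1 `N#Cc1ccc(NC(=O)c2c(NC(=O)C(F)(F)F)sc3c2CCCCC3)cc1`: 9110 nM
- compound 2 `COc1ccccc1NC(=O)c1c(NC(=O)C(F)(F)F)sc2c1CCCCC2`: > 50000 nM (a limit)

Compound 2 stands at the limit of > 50000 nM in this assay, at which 1 of the 2 values shown sits. Going by these compounds, this is a limit and not a number, so the size of any step away from compound 2 stays open on one side.

Compound 3 `O=C(Nc1ccccc1)c1c(NC(=O)C(F)(F)F)sc2c1CCCCC2` has hydrogen in place of methoxy on an aromatic carbon, ortho to a large group: hydrogen in place of methoxy on an aromatic carbon.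

For the measured compounds named here, one measured step bears on this, and only loosely, since it changes the same aryl group in a different way: an at least 5.4-fold higher number from compound 1 to compound 2 (0.73 log units; beyond the scatter). Compound 3 carries neither the 4-cyanophenyl of compound 1 nor the 2-methoxyphenyl of compound 2. A position between the two is therefore expected, with a lower number in this assay than compound 2 if the step can be resolved at all.

The expected step is an at least 1.6-fold lower number from compound 2 to compound 3 (0.22 log units; that floor lies within the scatter). For compound 3 the estimate is 30000 nM, with an expected range from 10000 nM to 50000 nM.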

Compound 3, half-maximal cytotoxic concentration: > 50000 nM
Compound 3: no number, only a limit (the forecaster's own chance of this, stated with the estimate: 35%); middle value at least 1.6-fold (0.22 log units) from the limit.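

In this assay compound 3 gives > 50000 nM, which is a limit and not a number. Hydrogen in place of cyano on an aromatic carbon gives an at least 5.4-fold higher number from compound 1 to compound 3 (0.73 log units; beyond the scatter), so the unsubstituted phenyl reaches the same limit without the methoxy, and in this set of compounds only the 4-cyanophenyl of compound 1 gives a readable value. The step for hydrogen in place of methoxy cannot be read, since it joins two limits: the limit of > 50000 nM in this assay, at which 2 of the 3 values shown sit.

Going by these compounds, whether methoxy changes the tolerated concentration at all remains open, since the true values of compound 2 and compound 3 both lie beyond the limit. Also open, on these data alone, is whether a different group on the phenyl, such as an amine or a carboxylic acid, would give a readable value as the nitrile does.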